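The source may report more compounds than this note shows. Statements on the series, on what has been measured and on what is new or still open speak of the compounds shown alone.

Measured compounds:
compound 1, `CCOC(=O)C1=Cc2ccccc2OC1(OCc1cn(-c2ccc(F)cc2)nn1)C(F)(F)F`, in a functional assay on DU-145 cells (Homo sapiens) for inhibition, read by MTT assay, with a stated time of 24 h (on this read-out lower numbers stand for stronger inhibition and higher numbers for weaker inhibition), compound 1 gives 8900 nM.
compound 2, `CCOC(=O)C1=Cc2ccccc2OC1(OCc1cn(-c2ccccc2)nn1)C(F)(F)F`, in this assay compound 2 sits at the limit of > 150000 nM.
compound 3, `CCOC(=O)C1=Cc2ccccc2OC1(OCc1cn(CC(=O)NC2CCCCC2)nn1)C(F)(F)F`, in this assay compound 3 gives 10200 nM.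

On the two numbers shown, compound 3 stands within the scatter of compound 1, with a 1.1-fold higher number from compound 1 to compound 3 (0.06 log units; within the scatter), so the two cannot be placed in order. The value of compound 2 is a limit of this assay and not a number, as the limit of > 150000 nM in this assay, at which 1 of the 3 values shown sits, shows.

Compound 4, `CCOC(=O)C1=Cc2ccccc2OC1(OCc1cn(-c2ccc([N+](=O)[O-])cc2)nn1)C(F)(F)F`, has yet to be measured. Its change from compound 3 is 4-nitrophenyl in place of (cyclohexylcarbamoyl)methyl on an aromatic nitrogen. Within the data shown here, two measured steps bear on this. From compound 1 to compound 3 the change at the same aromatic nitrogen was small, a 1.1-fold higher number from compound 1 to compound 3 (0.06 log units; within the scatter), while from compound 2 to compound 3 it was large, an at least 14-fold lower number from compound 2 to compound 3 (1.16 log units; beyond the scatter); the two aryl groups at this nitrogen thus fall far apart, with an at least 16-fold higher number from compound 1 to compound 2 (1.22 log units; beyond the scatter) between them. Compound 4 carries a third aryl group there, so the direction of its step in this assay is uncertain and a wide range is expected.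

Compound 4 is expected to give 12000 nM in this assay, within 3000 nM to 80000 nM. This means an expected step of a 1.2-fold higher number from compound 3 to compound 4 (0.07 log units; within the scatter).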

Compound 4, half-maximal inhibitory concentration: > 150000 nM
Compound 4 gave a limit, no number (the forecaster's own chance of this, stated with the estimate: 20%); middle value at least 12-fold (1.09 log units) from the limit.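

In this assay compound 4 gives a limit and not a number, and it is now the second compound shown to do so: the limit of > 150000 nM in this assay, at which 2 of the 4 values shown sit. With nitro in place of fluoro on an aromatic carbon there is an at least 16-fold higher number from compound 1 to compound 4 (1.22 log units; beyond the scatter), so of the three aryl groups shown on the aromatic nitrogen, only 4-fluorophenyl gives a number, while phenyl and 4-nitrophenyl both give limits; the step between compound 2 and compound 4 cannot be read, as both values are limits. With 4-nitrophenyl in place of (cyclohexylcarbamoyl)methyl there is an at least 14-fold higher number from compound 3 to compound 4 (1.16 log units; beyond the scatter), which shows that an aryl group on this nitrogen does not match the non-aromatic amide side chain of compound 3 unless it is the 4-fluorophenyl group of compound 1.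

The compounds shown leave open whether a chloro, methoxy or amine group on the same aromatic carbon would give a number in this assay or a limit. They also leave open how far the side chain of compound 3 can change, for instance with a cyclopentyl ring or an open hexyl chain on the amide nitrogen, before a number is lost.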